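Replacing tert-butyl with methylsulfanyl on compound 1

The source may report more compounds than this note shows. Statements on the series, on what has been measured and on what is new or still open speak of the compounds shown alone.

Values in a functional assay on MCF7 cells (Homo sapiens) for cytotoxicity; a lower number here means that less compound is needed, a higher number that more compound is needed for the effect
Compound 1 `COc1cc(/C=C\c2ccc(C(C)(C)C)cc2)cc(OC)c1OC` gives 1.57 uM
Compound 2 `COc1cc(/C=C/c2ccc(C(C)(C)C)cc2)cc(OC)c1OC` gives > 25 uM as a limit of the assay
Compound 3 `CCCOc1ccc(/C=C/c2cc(OC)c(OC)c(OC)c2)cc1` gives 12.5 uM

In this assay compound 1 stands lowest of the two true numbers at 1.57 uM and compound 3 comes next at 12.5 uM with a gap beyond the scatter. Compound 4 `COc1cc(/C=C\c2ccc(SC)cc2)cc(OC)c1OC` keeps the shared core and the Z double bond of compound 1. Among the compounds with values here, its one change is methylsulfanyl in place of tert-butyl on an aromatic carbon on an aromatic carbon.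

Two measured steps offer guidance. The large step of an at least 15-fold higher number from compound 1 to compound 2 (1.20 log units; beyond the scatter) goes with the fact that compounds 1 and 2 differ only in the configuration as drawn and also rests on the limit of > 25 uM in this assay, at which 1 of the 3 values shown sits, so it concerns the double bond, which compound 4 leaves as it is in compound 1. The only measured replacement of tert-butyl is an at least 2.0-fold lower number from compound 2 to compound 3 (0.30 log units; that floor lies within the scatter) and compound 3 thus gives a weak hint of a lower number, though with the double bond drawn E rather than Z. Methylsulfanyl itself has not yet been measured on this core.

A move to a lower number is expected, with the estimated step of a 3.1-fold lower number from compound 1 to compound 4 (0.50 log units; beyond the scatter) and wide uncertainty. The estimated value for compound 4 is 0.5 uM within an expected range of 0.05 uM to 5 uM as a best guess.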

Compound 4, concentration for half-maximal effect: 5.4 uM
Compound 4: middle estimate off by 11-fold (1.03 log units), on the low side; measured number above the stated range.
By their numbers in this assay, from the lowest: compound 1; then compound 4; then compound 3. At a limit, above all of these: compound 2.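

Within the data shown here, with the Z double bond held constant, this is the first direct reading of a tert-butyl replacement at this position, and in this assay it shows a 3.4-fold higher number from compound 1 to compound 4 (0.54 log units; beyond the scatter). The only earlier replacement of tert-butyl started from compound 2, whose value is a limit and whose double bond is drawn E, so it gave no true size for the change, whereas this step joins two true numbers on the Z double bond. The change swaps an all-carbon group for one with fewer heavy atoms, a sulfur atom and a hydrogen-bond acceptor, but none of the facts at hand bears on which of these differences matters for the step.

From the compounds shown here alone, it remains open whether the higher number follows from the sulfur atom, from the loss of the branched carbon group, or from something else, as a single replacement cannot separate these. Going by these compounds, it is also open how an ethyl group, an amine or a carboxylic acid at this position would compare with tert-butyl on the Z double bond, and whether the propoxy of compound 3 would give a lower or higher number there.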